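The source may report more compounds than this note shows. Statements on the series, on what has been measured and on what is new or still open speak of the compounds shown alone.

Measured in a functional assay on the whole organism with Mus musculus as the target; a higher number here means that more compound is needed for the effect, a lower number that less compound is needed:
compound 1 `NC(=O)/C=C1\CCc2c(F)cc(F)cc21` gives 69 mg/kg
compound 2 `O=C(/C=C1\CCc2c(F)cc(F)cc21)NC1CC1` gives 62 mg/kg
compound 3 `O=C(/C=C1\CCc2c(F)ccc(F)c21)NC1CC1` gives 59 mg/kg

Compound 2 and compound 1 share one core and differ by hydrogen in place of cyclopropyl on an amide-type nitrogen; the step is a 1.1-fold higher number from compound 2 to compound 1 (0.05 log units; within the scatter). Compound 3 carries the same cyclopropylcarbamoyl group as compound 2 on a core built of the same atoms joined differently; the difference between the two cores is not broken down here, and the values of compound 2 and compound 3 lie within the usual scatter of each other. All three values in this assay sit within that scatter of one another, so no order among them is drawn.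

Compound 4 `NC(=O)/C=C1\CCc2c(F)ccc(F)c21` has not been measured. It stands to compound 3 as compound 1 stands to compound 2: hydrogen in place of cyclopropyl on an amide-type nitrogen, the same change at the same kind of amide-type nitrogen. The step from compound 3 to compound 4 is expected to be a 1.1-fold higher number from compound 3 to compound 4 (0.04 log units; within the scatter). This rests on compound 2 and compound 1, where the same change made a 1.1-fold higher number from compound 2 to compound 1 (0.05 log units; within the scatter), and on compound 3 as the starting point with 59 mg/kg. Compound 4 is therefore expected to give 65 mg/kg, estimated between 40 mg/kg and 105 mg/kg.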

Compound 4, dose for half-maximal effect: 56 mg/kg
Estimate against measurement, compound 4: 1.2-fold (0.06 log units) above, within the range that was stated.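

In this assay, hydrogen in place of cyclopropyl on the amide-type nitrogen gives a 1.1-fold lower number from compound 3 to compound 4 (0.02 log units; within the scatter). Set beside the earlier step on the other core, the two steps cannot be told apart: the same change on two cores in this assay, a 1.1-fold higher number (0.05 log units; within the scatter) from compound 2 to compound 1 and a 1.1-fold lower number (0.02 log units; within the scatter) from compound 3 to compound 4, 1.2-fold (0.07 log units) apart, within the scatter of two such steps This shows that on these two cores the change from cyclopropylcarbamoyl to carbamoyl leaves the value within the scatter, but it does not show that the same would hold on a further core, and two steps this small are a weak test of transfer, since neither gives a real effect to carry over and a small effect on either core is not excluded.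

Only hydrogen and cyclopropyl appear on that nitrogen among the compounds shown, so a longer alkyl chain, a phenyl ring or a chain ending in an amine or a carboxylic acid remains open there. Going by these compounds, both cores carry two fluorines, so whether the step holds on a core with chlorine in their place also remains open.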